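Trifluoromethoxy for trifluoromethyl on two related cores

The source may hold more compounds than are shown below. What is called first, only, known or untested is meant among the compounds shown, and "the series" means these compounds.

Compound 1 `CC(O)(CSc1ccc(C(F)(F)F)cc1)C(=O)Nc1cccc(S(F)(F)(F)(F)F)c1` and compound 2 `CC(O)(CSc1ccc(OC(F)(F)F)cc1)C(=O)Nc1cccc(S(F)(F)(F)(F)F)c1` share one core; compound 3 `CC(O)(COc1ccccc1C(F)(F)F)C(=O)Nc1ccc(S(F)(F)(F)(F)F)cc1` and compound 4 `CC(O)(COc1ccccc1OC(F)(F)F)C(=O)Nc1ccc(S(F)(F)(F)(F)F)cc1` share another, and the difference between the two cores is not broken down here. In a functional assay on DU-145 cells (Homo sapiens) for antiproliferative activity, read by propidium iodide staining, with a stated time of 96 h (a lower number here means a stronger inhibitor, a higher number a weaker inhibitor), compound 1 gives 27200 nM and compound 2 gives 24700 nM. The step of a 1.1-fold lower number from compound 1 to compound 2 (0.04 log units; within the scatter) rests on (trifluoromethoxy in place of trifluoromethyl on an aromatic carbon). Compound 3 gives 7100 nM, the lowest of the three measured numbers. Compound 4 is not yet measured; it differs from compound 3 by trifluoromethoxy in place of trifluoromethyl on an aromatic carbon, the same kind of change as between compound 1 and compound 2, though there the entering group sits para to a large group and here ortho to a large group. Because a 1.1-fold lower number from compound 1 to compound 2 (0.04 log units; within the scatter) stayed within the scatter, a comparably small step is expected here, namely a 1.1-fold lower number from compound 3 to compound 4 (0.04 log units; within the scatter). Compound 4 is accordingly estimated at 6500 nM, with an expected range from 2500 nM to 17000 nM.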

Compound 4, half-maximal inhibitory concentration: 16800 nM
For compound 4 the middle estimate is 2.6-fold (0.41 log units) below the measured one; the range from low to high includes it.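

In this assay, trifluoromethoxy in place of trifluoromethyl gives a 2.4-fold higher number from compound 3 to compound 4 (0.37 log units; beyond the scatter), a modest step. Set beside the step on the other core, it does not separate from it: the same change on two cores in this assay, a 1.1-fold lower number (0.04 log units; within the scatter) from compound 1 to compound 2 and a 2.4-fold higher number (0.37 log units; beyond the scatter) from compound 3 to compound 4, 2.6-fold (0.42 log units) apart, within the scatter of two such steps. This gives no sign that the outcome of the change depends on the core, but two pairs cannot establish that it carries over with the same size, and the place of the entering group, ortho to a large group in compound 4, cannot be separated from the difference between the cores.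

Going by these compounds, whether the step holds on a third core remains open. So does how a methoxy group, a chlorine atom or a nitrile would compare at that place on the ring.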